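Acylation of the ring nitrogen in tetrahydroquinoline carboxamides

The source may hold more compounds than are shown below. What is called first, only, known or untested is meant among the compounds shown, and "the series" means these compounds.

Measured compounds: compound 1 `O=C(Nc1ccccc1O)C1CCc2ccccc2N1` gives 3990 nM in a functional assay on ACHN cells (Homo sapiens) for cytotoxicity, read by sulforhodamine B assay, with a stated time of 72 h; on this read-out lower numbers stand for stronger inhibition of growth and higher numbers for weaker inhibition of growth; compound 2 `O=C(Nc1cc(C(F)(F)F)cc(C(F)(F)F)c1)C1CCc2ccccc2N1` gives 8190 nM; compound 3 `O=C(Nc1cc(C(F)(F)F)cc(C(F)(F)F)c1)C1CCc2ccccc2N1C(=O)c1cccc(Cl)c1` gives 813 nM.

Compound 1 and compound 2 differ in the anilide part; the difference between the two cores is not broken down here. Compound 3 is compound 2 carrying a ((3-chlorophenyl)carbonyl in place of hydrogen on a nitrogen on an aromatic ring in a ring), and this change gave a 10-fold lower number from compound 2 to compound 3 (1.00 log units; beyond the scatter). Compound 4 `O=C(Nc1ccccc1O)C1CCc2ccccc2N1C(=O)c1cccc(Cl)c1` is compound 1 carrying the same change, ((3-chlorophenyl)carbonyl in place of hydrogen on a nitrogen on an aromatic ring in a ring), at the same place. For the measured compounds named here, the step from compound 1 to compound 4 is therefore expected to resemble the one seen from compound 2 to compound 3, because the step of a 10-fold lower number from compound 2 to compound 3 (1.00 log units; beyond the scatter) is the only guide available, although a single precedent leaves the size uncertain. Compound 4 is accordingly expected to give 600 nM in this assay, estimated within 150 nM to 2500 nM, which would mean a 6.7-fold lower number from compound 1 to compound 4 (0.82 log units; beyond the scatter).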

Compound 4, concentration for 50% growth inhibition: 17200 nM
The estimate for compound 4 lay 29-fold (1.46 log units) below the measured number, outside the stated range (above it).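

In this assay, the (3-chlorophenyl)carbonyl group on the ring nitrogen did not carry over from one core to the other: on the core of compound 1 it gave a 4.3-fold higher number from compound 1 to compound 4 (0.63 log units; beyond the scatter), so the step ran in the opposite direction to the one on the other core: the same change on two cores in this assay, a 10-fold lower number (1.00 log units; beyond the scatter) from compound 2 to compound 3 and a 4.3-fold higher number (0.63 log units; beyond the scatter) from compound 1 to compound 4, 43-fold (1.64 log units) apart, beyond the scatter of two such steps

The size and even the direction of this step thus depended on the core in these two pairs, and a step seen on one core was no guide to the other. This does not show why the two steps part, and one pair per core says nothing about other anilides or other acyl groups.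

The compounds shown leave open whether the reversal follows the hydroxy group or the trifluoromethyl groups on the anilide. They also leave open how an anilide carrying a methoxy group, or an acetyl group on the ring nitrogen, would behave.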